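A few compounds are considered here, and "the series" means these few. Any claim that something is new, unique, unknown or untested is made for them only; others in the source may bear on it.

Of the compounds shown here, three built on one shared core have been tested in a functional assay on DU-145 cells (Homo sapiens) for inhibition, read by MTT assay, with a stated time of 24 h; a lower number here means a stronger inhibitor, a higher number a weaker inhibitor. Compound 1 `CCOC(=O)C1=Cc2ccccc2OC1(OCc1cc(-c2ccc(C)cc2)no1)C(F)(F)F` gives only a limit there, > 150000 nM. Compound 2 `CCOC(=O)C1=Cc2ccccc2OC1(OCc1cc(-c2ccc(OC)cc2)no1)C(F)(F)F` likewise gives only a limit, > 150000 nM. For the measured compounds named here, compound 3 `CCOC(=O)C1=Cc2ccccc2OC1(OCc1cc(-c2ccc(Cl)cc2)no1)C(F)(F)F` is the sole compound with an actual number in this assay, 18200 nM, so it stands alone as the one readable value among the three. Measured against the limits, the change from compound 1 to compound 3 is an at least 8.2-fold lower number from compound 1 to compound 3 (0.91 log units; beyond the scatter), and from compound 2 to compound 3 it is an at least 8.2-fold lower number from compound 2 to compound 3 (0.91 log units; beyond the scatter); between compound 1 and compound 2 there is a step that the two limits leave unreadable from compound 1 to compound 2.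

Compound 4 `CCOC(=O)C1=Cc2ccccc2OC1(OCc1cc(-c2cccc(C(F)(F)F)c2)no1)C(F)(F)F` differs from compound 3 in one place: 3-(trifluoromethyl)phenyl in place of 4-chlorophenyl on an aromatic carbon. Neither measured step bears directly on this change, since both exchange methyl or methoxy for chloro, and none exchanges chloro for trifluoromethyl. Going by the values given here, with no close precedent, the expected step from compound 3 to compound 4 is a 1.6-fold higher number from compound 3 to compound 4 (0.22 log units; within the scatter), a shift not firmly beyond the scatter in either direction. Compound 4 is therefore estimated at 30000 nM in this assay, within a range of 6000 nM to 150000 nM.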

Compound 4, half-maximal inhibitory concentration: 57300 nM
For compound 4 the middle estimate is 1.9-fold (0.28 log units) below the measured one; the range from low to high includes it.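

The new result gives this position, the aromatic carbon next to the ring nitrogen, a second readable value, and 3-(trifluoromethyl)phenyl does not match 4-chlorophenyl there: in this assay there is a 3.1-fold higher number from compound 3 to compound 4 (0.50 log units; beyond the scatter). Even so, the new group still compares well with the two groups that gave only limits, with an at least 2.6-fold lower number from compound 2 to compound 4 (0.41 log units; beyond the scatter) and an at least 2.6-fold lower number from compound 1 to compound 4 (0.41 log units; beyond the scatter). These last two steps give only a minimum size, not an exact one: the limit of > 150000 nM in this assay, at which 2 of the 4 values shown sit.

Compound 3 and compound 4 differ both in the substituent and in its numbered place on the phenyl, so the compounds shown cannot separate those two changes. Also open, from the compounds shown here alone, is how an amine or a carboxylic acid on that phenyl would read in this assay.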